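The compounds below may be only part of what the source reports. "The series", "measured", "known", "first", "only" and "open" are said of these compounds alone.

Notes on the series in a functional assay on HCT-116 cells (Homo sapiens) for inhibition, read by MTT assay, with a stated time of 72 h (on this read-out lower numbers stand for stronger inhibition of growth and higher numbers for weaker inhibition of growth), follow. Here compound 3 (`O=C(O)/C=C/c1ccncc1-c1ccc2ccccc2c1`) gives > 30000 nM as a limit of the assay and not a number. Compound 1 (`NNC(=O)CCc1ccncc1-c1ccc2ccccc2c1`) gives > 30000 nM as a limit too. Compound 2 (`Cn1ncc2cc(-c3cnccc3/C=C/C(=O)N3CCOCC3)ccc21`) offers no reading ("not determined" (no result reported)). Compound 3 therefore sits at the limit of > 30000 nM in this assay, at which 2 of the 3 values shown sit, and has no number to step from.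

Compound 4 (`NC(=O)/C=C/c1ccncc1-c1ccc2ccccc2c1`) differs from compound 3 by amino in place of hydroxy on a carbonyl carbon in the change of amino in place of hydroxy on a carbonyl carbon, so 2-carboxyethenyl becomes 2-carbamoylethenyl. Within the data shown here, the only measured step that bears on it is a step that the two limits leave unreadable from compound 1 to compound 3 and so gives no size to carry over. No direction can be drawn from it, and compound 4 is expected to stay near the same limit in this assay with a fair chance of another limit. The expected step is a number no higher from compound 3 to compound 4 (the limit leaves the size open) with no readable direction. For compound 4 the estimate is 30000 nM with an expected range of 10000 nM to 60000 nM on the same read-out.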

Compound 4, concentration for 50% growth inhibition: 12100 nM
Compound 4: the middle estimate sits 2.5-fold (0.39 log units) above what was measured, and the stated range covers the measured number.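

In this assay, among these compounds, the carbonyl carbon of this side chain is the first place where a change can be read: amino in place of hydroxy gives an at least 2.4-fold lower number from compound 3 to compound 4 (0.39 log units; beyond the scatter) and turns 2-carboxyethenyl into 2-carbamoylethenyl. The swap of 2-(aminocarbamoyl)ethyl for 2-carbamoylethenyl on an aromatic carbon gives an at least 2.4-fold lower number from compound 1 to compound 4 (0.39 log units; beyond the scatter) and points the same way, while the remaining step among these compounds cannot be read. Both steps have an open size because each starts from a limit of the assay and not a number: the limit of > 30000 nM in this assay, at which 2 of the 4 values shown sit.

The compounds shown leave open whether a methylamide or dimethylamide would hold or extend this gain. They also leave open how a saturated 2-carbamoylethyl chain would compare, which would separate the double bond from the change at the chain end.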